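A few compounds are considered here, and "the series" means these few. Any claim that something is new, unique, unknown or untested is made for them only; others in the source may bear on it.

Working notes on the series, all read in a physicochemical assay for lipophilicity, read by HPLC, using the shake flask method, measured as octanol-water partition; a lower number here means a more polar compound, a higher number a more lipophilic compound. Compound 1 (`O=C(C1CC12CCN(C1CCCCC1)CC2)N1CCN(C2CCCCC2)CC1`) has no number, its entry being "not determined" (no result reported). Compound 2 (`CC(C)N1CCC2(CC1)CC2C(=O)N1CCN(C2CCCCC2)CC1`) gives 0.74 and compound 3 (`O=C(C1CC12CCN(c1ccccc1)CC2)N1CCN(C2CCCCC2)CC1`) gives 3.63, the higher of the two numbers available.

Next is compound 4 (`O=C(C1CC12CCN(Cc1ccccc1)CC2)N1CCN(C2CCCCC2)CC1`), with benzyl in place of phenyl on an amine nitrogen in a ring.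

Within the data shown here, only one measured step bears on this change: a number 2.89 log units higher from compound 2 to compound 3 (beyond the scatter), a large step beyond the scatter, with phenyl in place of isopropyl at the same nitrogen. Benzyl keeps the aromatic ring of phenyl, but, like isopropyl, it joins that nitrogen through a non-aromatic carbon. A partial return towards compound 2 is therefore expected: a downward step beyond the scatter, though smaller than the measured one. A single step is a thin basis, so the range is kept wide.

The estimated step is a number 1.43 log units lower from compound 3 to compound 4 (beyond the scatter). Compound 4 is expected at 2.2, with an estimated range from 1.5 to 3.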

Compound 4, distribution coefficient: 2.81
Beside the measured number, compound 4's estimate is 0.61 log units below it; low and high end bracket the measured number.
By their numbers in this assay, from the lowest: compound 2; then compound 4; then compound 3.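

In this assay, benzyl in place of phenyl on the amine nitrogen in a ring gives a number 0.82 log units lower from compound 3 to compound 4 (beyond the scatter), so two groups that both carry the same aromatic ring still give separate numbers at this position. Benzyl in place of isopropyl at that nitrogen gives a number 2.07 log units higher from compound 2 to compound 4 (beyond the scatter), a larger step than the one from phenyl, which places compound 4 closer to compound 3 than to compound 2 and shows that most of the gain seen with phenyl survives in benzyl. Nothing measured on these compounds accounts for this order of the three groups.

As far as these compounds go, whether a longer chain such as phenethyl on the same nitrogen would continue this downward step remains open. So does the effect of a carboxylic acid or an amine on the aromatic ring of benzyl.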